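Indole-2-carboxamide in place of the indolylethyl chain

This account rests on a few compounds, and the source may have more. Where it says the series, first, only, none or still open, it means among the compounds named here.

Compound 3 `CC(C)(C)OC(=O)CN1C(=O)C(NC(=O)CCc2c[nH]c3ccccc23)CCc2ccccc21` carries a 2-(1H-indol-3-yl)ethyl group on the carbonyl carbon of its amide. In an assay for binding affinity to Cholecystokinin receptor (Rattus norvegicus), read by CCK-8 assay (a lower number here means a stronger inhibitor, a higher number a weaker inhibitor), compound 3 gives 2000 nM, the highest number among the three measured compounds. Compound 1 `CC(C)(C)OC(=O)CN1C(=O)C(NC(=O)c2ccc(Cl)cc2)CCc2ccccc21` gives 130 nM and compound 2 `CC(C)(C)OC(=O)CN1C(=O)C(NC(=O)c2ccc(Cl)c(Cl)c2)CCc2ccccc21` gives 28 nM; the step of a 4.6-fold lower number from compound 1 to compound 2 (0.67 log units; beyond the scatter) is modest, whereas a 15-fold higher number from compound 1 to compound 3 (1.19 log units; beyond the scatter) and a 71-fold higher number from compound 2 to compound 3 (1.85 log units; beyond the scatter) are both large.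

Compound 4 `CC(C)(C)OC(=O)CN1C(=O)C(NC(=O)c2cc3ccccc3[nH]2)CCc2ccccc21` differs from compound 3 in one place: 1H-indol-2-yl in place of 2-(1H-indol-3-yl)ethyl on a carbonyl carbon. This replaces the chain with an aromatic group joined directly to the carbonyl carbon, the arrangement present in compound 1 and compound 2. The two large steps that bear on this change, a 15-fold higher number from compound 1 to compound 3 (1.19 log units; beyond the scatter) and a 71-fold higher number from compound 2 to compound 3 (1.85 log units; beyond the scatter), both ran in the direction of weaker binding when the aryl amide was exchanged for the chain, so the reverse exchange is expected to give a large step toward a lower number. The step expected for compound 4 is a 40-fold lower number from compound 3 to compound 4 (1.60 log units; beyond the scatter). Compound 4 is therefore estimated at 50 nM, within a range of 10 nM to 300 nM.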

Compound 4, half-maximal inhibitory concentration: 7 nM
For compound 4 the middle estimate is 7.1-fold (0.85 log units) above the measured one; the measured number lies below the stated range.
By their numbers in this assay, from the lowest: compound 4; then compound 2; then compound 1; then compound 3.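

In this assay the 1H-indol-2-yl group gives a 290-fold lower number from compound 3 to compound 4 (2.46 log units; beyond the scatter), so at this carbonyl carbon the same count of aromatic rings and hydrogen-bond donors can go with very different numbers, depending on how the indole is attached. The earlier compounds shown here reached their lowest number with 3,4-dichlorophenyl, but a group without chlorine now goes lower, with a 4.0-fold lower number from compound 2 to compound 4 (0.60 log units; beyond the scatter) and a 19-fold lower number from compound 1 to compound 4 (1.27 log units; beyond the scatter), leaving compound 4 lowest of the four. No measurement shown here explains the size of these steps.

Compound 4 changes the attachment point on the indole and removes the chain together, so the two changes cannot be told apart. Going by these compounds, whether 1H-indol-3-yl joined directly to the carbonyl carbon, or a methyl group in place of the indole hydrogen on nitrogen, would keep the low number remains open.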